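Butyl in place of 3-chlorophenyl on the piperazine nitrogen

This account rests on a few compounds, and the source may have more. Where it says the series, first, only, none or still open, it means among the compounds named here.

Compound 1 `CCOC(=O)N1CCN(C(=S)SCC(O)Cn2c([N+](=O)[O-])cnc2C)CC1` gives 1610000 nM in a toxicity assay on HeLa cells (Homo sapiens) for cytotoxicity, read by MTT assay, with a stated time of 24 h; a lower number here means a stronger inhibitor, a higher number a weaker inhibitor.
Compound 2 `COc1ccccc1N1CCN(C(=S)SCC(O)Cn2c([N+](=O)[O-])cnc2C)CC1` reaches only the limit of > 5000000 nM in this assay.
Compound 3 `Cc1ncc([N+](=O)[O-])n1CC(O)CSC(=S)N1CCN(c2cccc(Cl)c2)CC1` gives 1080000 nM in this assay.

Compound 3 holds the lowest of the two numbers; compound 1 stands nearest, a 1.5-fold lower number from compound 1 to compound 3 (0.17 log units; within the scatter). Compound 2 sits at a limit (the limit of > 5000000 nM in this assay, at which 1 of the 3 values shown sits). Compound 4 `CCCCN1CCN(C(=S)SCC(O)Cn2c([N+](=O)[O-])cnc2C)CC1` differs from compound 3 by butyl in place of 3-chlorophenyl on an amine nitrogen in a ring. Going by the values given here, no measured step involves butyl; the steps onto this nitrogen were a 1.5-fold lower number from compound 1 to compound 3 (0.17 log units; within the scatter) and an at least 4.6-fold lower number from compound 2 to compound 3 (0.66 log units; beyond the scatter). Since one step was within the scatter and the other only modest, the step of a 1.4-fold higher number from compound 3 to compound 4 (0.14 log units; within the scatter) is expected to stay near the scatter. Compound 4 is therefore estimated at 1500000 nM, with a range from 700000 nM to 4000000 nM.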

Compound 4, half-maximal inhibitory concentration: 1910000 nM
Beside the measured number, compound 4's estimate is 1.3-fold (0.10 log units) below it; the range from low to high includes it.
By their numbers in this assay, from the lowest: compounds 3, 1 and 4 (each within the scatter of the next). At a limit, above all of these: compound 2.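

In this assay, butyl brings the first plain carbon chain to this amine nitrogen, and the number stays within the scatter of both neighbours: a 1.8-fold higher number from compound 3 to compound 4 (0.25 log units; within the scatter), and a 1.2-fold higher number from compound 1 to compound 4 (0.07 log units; within the scatter). An aromatic ring on this nitrogen is thus not required to hold this level, and only the 2-methoxyphenyl group stands apart, with an at least 2.6-fold lower number from compound 2 to compound 4 (0.41 log units; beyond the scatter). Compound 2 remains at a limit: the limit of > 5000000 nM in this assay, at which 1 of the 4 values shown sits.

As far as these compounds go, whether a shorter chain, a longer chain or a chain ending in a hydroxyl or an amine would stay at this level remains open. So does whether a methoxy group elsewhere on the phenyl ring would stand apart as 2-methoxyphenyl does.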